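The source may report more compounds than this note shows. Statements on the series, on what has been measured and on what is new or still open speak of the compounds shown alone.

Compound 1 `O=c1ccoc2cc(OCc3cn(Cc4ccc(Cl)cc4Cl)nn3)ccc12` in a functional assay on MDA-MB-231 cells (Homo sapiens) for cytotoxicity, read by MTT assay, with a stated time of 48 h (on this read-out higher numbers stand for weaker inhibition and lower numbers for stronger inhibition), reaches only a limit, > 100000 nM. Compound 2 `O=c1ccoc2cc(OCc3cn(Cc4ccccc4F)nn3)ccc12`, which carries 2-fluorophenyl on a saturated chain carbon bound to an aromatic nitrogen, gives 29800 nM in this assay. Compound 3 `N#Cc1ccc(Cn2cc(COc3ccc4c(=O)ccoc4c3)nn2)cc1`, with 4-cyanophenyl at that place, again sits at a limit, > 100000 nM. The measured steps read an at least 3.3-fold lower number from compound 1 to compound 2 (0.52 log units; beyond the scatter), an at least 3.3-fold higher number from compound 2 to compound 3 (0.52 log units; beyond the scatter) and a step that the two limits leave unreadable from compound 1 to compound 3; since two of three values sit at the limit of > 100000 nM in this assay, at which 2 of the 3 values shown sit, the moves are hard to size. Compound 4 `O=c1ccoc2cc(OCc3cn(Cc4ccccc4Br)nn3)ccc12` has not yet been measured and differs from compound 1 by 2-bromophenyl in place of 2,4-dichlorophenyl on a saturated chain carbon bound to an aromatic nitrogen. The closest guide is the change from compound 1 to compound 2, which gave an at least 3.3-fold lower number from compound 1 to compound 2 (0.52 log units; beyond the scatter). Compound 4 is therefore expected near 45000 nM, between 15000 nM and 150000 nM. This means an expected step of an at least 2.2-fold lower number from compound 1 to compound 4 (0.34 log units; beyond the scatter).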

Compound 4, half-maximal inhibitory concentration: > 100000 nM
Compound 4 was reported as a limit; the forecaster's own chance of this, stated with the estimate: 40%; middle value at least 2.2-fold (0.34 log units) from the limit.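

With bromo in place of fluoro on an aromatic carbon and nothing else changed, the result gives an at least 3.3-fold higher number from compound 2 to compound 4 (0.52 log units; beyond the scatter) in this assay, so this one swap is enough to lose the readable value. Compound 4 is reported only as a limit, and its steps to compound 1 and compound 3 cannot be read. Compound 2 now stands alone in giving a number rather than a limit: the limit of > 100000 nM in this assay, at which 3 of the 4 values shown sit.

Still open, as far as these compounds go, is whether a plain phenyl or a phenyl carrying an amine at this place would give a readable number, as compound 2 does.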